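This account rests on a few compounds, and the source may have more. Where it says the series, first, only, none or still open, it means among the compounds named here.

Measured compounds in a functional assay on A549 cells (Homo sapiens) for inhibition, read by XTT assay, with a stated time of 48 h; on this read-out lower numbers stand for stronger inhibition and higher numbers for weaker inhibition:

compound 1 `COc1ccc(C(=O)/C(=C/c2ccc(Cl)cc2Cl)CCOC(C)=O)cc1` gives 69200 nM
compound 2 `COc1ccc(C(=O)/C(=C/c2c(F)c(F)c(F)c(F)c2F)CCOC(C)=O)cc1` gives 58100 nM
compound 3 `COc1ccc(C(=O)/C(=C/c2ccc(Cl)cc2Cl)CC(C)OC(C)=O)cc1` gives 40300 nM

Compound 1 and compound 3 share a core and differ in one place, (methyl in place of hydrogen on a saturated chain carbon bound to an oxygen next to a carbonyl group and a saturated chain carbon). This change gave a 1.7-fold lower number from compound 1 to compound 3 (0.23 log units; within the scatter), so within this series it has not produced a shift that can be separated from repeat-measurement noise. Compound 2 carries a different core; the difference between the core of compound 1 and the core of compound 2 is not broken down here. Compound 2 and compound 1 return values that lie within the usual scatter of each other, and the same holds for compound 2 against compound 3, so no order among the three measured compounds can be claimed.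

Compound 4 `COc1ccc(C(=O)/C(=C/c2c(F)c(F)c(F)c(F)c2F)CC(C)OC(C)=O)cc1` is not yet measured. It stands to compound 2 as compound 3 stands to compound 1: methyl in place of hydrogen on a saturated chain carbon bound to an oxygen next to a carbonyl group and a saturated chain carbon. The place lines of the two changes are the same word for word, so this is the same change made on the other core.

Going by the values given here, for compound 4 in this assay the step is expected to be a 1.5-fold lower number from compound 2 to compound 4 (0.16 log units; within the scatter), because a 1.7-fold lower number from compound 1 to compound 3 (0.23 log units; within the scatter) is the only measured instance of this change and it stayed within the scatter. Compound 4 is therefore estimated at 40000 nM, with a likely range from 20000 nM to 80000 nM.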

Compound 4, half-maximal inhibitory concentration: 91700 nM
The estimate for compound 4 lay 2.3-fold (0.36 log units) below the measured number, and the stated range ends below it.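

In this assay, the change from 2-acetoxyethyl to 2-acetoxypropyl on the core of compound 2 gave a 1.6-fold higher number from compound 2 to compound 4 (0.20 log units; within the scatter), so on this core alone the step cannot be separated from repeat-measurement noise. Neither step on its own stands clear of the scatter, but the two differ by more than the scatter allows for a pair of such steps, so a single shift cannot be carried unchanged from one core to the other: the same change on two cores in this assay, a 1.7-fold lower number (0.23 log units; within the scatter) from compound 1 to compound 3 and a 1.6-fold higher number (0.20 log units; within the scatter) from compound 2 to compound 4, 2.7-fold (0.43 log units) apart, beyond the scatter of two such steps This shows only that the outcome of the change depends on the core in this four-compound set; with one pair on each core, it does not give a reliable size for the step on either core, nor does it identify which feature of the cores accounts for the difference.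

The compounds shown leave open whether a longer chain on the same saturated chain carbon, such as ethyl in place of methyl, would give a step beyond the scatter on either core. They also leave open how the two cores would respond if a hydroxyl group or an amine stood in place of the acetoxy group.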